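Aryl Exchange on the Shared Core: Compound 2 to Compound 3

The source may hold more compounds than are shown below. What is called first, only, known or untested is meant among the compounds shown, and "the series" means these compounds.

Measured compounds:
compound 1 `CC(C)(C)Cc1c(-c2cc(F)ccc2F)sc(N)c1C(=O)c1ccc(Cl)cc1` — 3%
compound 2 `CC(C)(C)Cc1c(-c2c(F)cccc2F)sc(N)c1C(=O)c1ccc(Cl)cc1` — 1%

In an assay on CHO cells for displacement of a labelled ligand from adenosine receptor A1 (Homo sapiens), read by scintillation counting, tested at 10 uM (on this read-out lower numbers stand for less inhibition and higher numbers for more inhibition at the one concentration tested (going by the name of the read-out)), compound 1 gives 3%. In the same test compound 2 gives 1%. Compound 2 thus stands lowest of the two numbers, with compound 1 nearest; the step of a number 2 percentage points lower from compound 1 to compound 2 (within the scatter) lies within the scatter, so the two compounds cannot be told apart on this read-out.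

Compound 3 `COc1cccc(-c2sc(N)c(C(=O)c3ccc(Cl)cc3)c2CC(C)(C)C)c1` is the unmeasured member of the set. It differs from compound 2 by 3-methoxyphenyl in place of 2,6-difluorophenyl on an aromatic carbon. Among the measured compounds shown here, only one measured step exists, and it exchanged one difluorophenyl for another; it bears on the present change only in showing that swapping the aryl group at this place left the read-out unchanged, as a number 2 percentage points lower from compound 1 to compound 2 (within the scatter) shows. For the measured compounds named here, no measured pair exchanges fluorine substituents for a methoxy group, so that part of the change is untested here.

On this basis compound 3 is expected to remain near the low values of the measured pair, with an estimated step of a number 4 percentage points higher from compound 2 to compound 3 (within the scatter) from compound 2, not beyond the scatter. The estimate for compound 3 is 5%, with a range from -8% to 22%.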

Compound 3, a percentage reported as inhibition, at one concentration (the size of the read-out at that concentration, not a potency): 1%
Estimate against measurement, compound 3: 4 percentage points above, within the range that was stated.
By their numbers in this assay, from the lowest: compounds 2, 3 and 1 (each within the scatter of the next).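

The earlier pair exchanged only one difluorophenyl for another on the aromatic carbon next to the ring sulfur. Compound 3 extends the exchange to a phenyl ring with no fluorine, and 3-methoxyphenyl, which carries one hydrogen-bond acceptor where 2,6-difluorophenyl carries none, gives no change at the digits printed from compound 2 to compound 3 (within the scatter) in this assay and a number 2 percentage points lower from compound 1 to compound 3 (within the scatter) against the 2,5-difluorophenyl compound. At this position, therefore, neither moving the fluorines nor replacing both with a methoxy group separates the three compounds on this read-out, and none of them goes against that reading. Nothing available bears on why the read-out stays the same across these aryl groups.

What the compounds shown leave open is whether any group at this place can move the read-out beyond the scatter, since a phenyl ring carrying an amine or a carboxylic acid, or a longer chain in place of the ring, would be a sharper test than the substituents compared here. They also leave open how the read-out responds to changes at the neopentyl group, the (4-chlorophenyl)carbonyl group or the amino group, which stay the same in all three compounds.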